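Swapping an Alkynyl Thiophene Arm for a Furan Ring

A few compounds are considered here, and "the series" means these few. Any claim that something is new, unique, unknown or untested is made for them only; others in the source may bear on it.

Measured compounds:
- compound 1 `Nc1ncnn2c([C@@H]3O[C@H](CO)[C@@H](O)[C@H]3O)cc(C#Cc3cccs3)c12`: 50100 nM
- compound 2 `Nc1ncnn2c([C@@H]3O[C@H](CO)[C@@H](O)[C@H]3O)cc(-c3ccc(F)cc3)c12`: > 100000 nM
- compound 3 `Nc1ncnn2c([C@@H]3O[C@H](CO)[C@@H](O)[C@H]3O)cc(-c3ccc(Cl)cc3)c12`: 40200 nM

In a functional assay on Z-138 cells (Homo sapiens) for antiproliferative activity, with a stated time of 72 h (on this read-out lower numbers stand for stronger inhibition and higher numbers for weaker inhibition), compound 1 gives 50100 nM. Of the two numbers reported, compound 1 has the highest, and its nearest neighbour is compound 3, which gives 40200 nM; these two sit within the usual scatter of each other, so no order can be read between them. Compound 2 gives only > 100000 nM, a limit of the assay rather than a number, at the limit of > 100000 nM in this assay, at which 1 of the 3 values shown sits. All three compounds are weak inhibitors on this read-out.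

Compound 4 `Nc1ncnn2c([C@@H]3O[C@H](CO)[C@@H](O)[C@H]3O)cc(-c3ccoc3)c12` has not been measured. It differs from compound 1 in one place: furan-3-yl in place of 2-(thiophen-2-yl)ethynyl on an aromatic carbon. Among the measured compounds shown here, no measured step makes exactly this change, but two steps replace the same leaving group with an aromatic ring: a 1.2-fold lower number from compound 1 to compound 3 (0.10 log units; within the scatter) and an at least 1.9-fold higher number from compound 1 to compound 2 (0.30 log units; that floor lies within the scatter). One stays within the scatter, the other goes toward weaker inhibition and ends at a limit. A small, flat five-membered ring in place of the longer arm is therefore expected to give either no change beyond the scatter or a shift toward weaker inhibition, and the chance of a limit is real.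

Compound 4 is estimated at 65000 nM, with a range from 25000 nM to 160000 nM. This corresponds to an expected 1.3-fold higher number from compound 1 to compound 4 (0.11 log units; within the scatter).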

Compound 4, half-maximal inhibitory concentration: 300 nM
For compound 4 the middle estimate is 220-fold (2.34 log units) above the measured one, and the stated range ends above it.
By their numbers in this assay, from the lowest: compound 4; then compounds 3 and 1 (each within the scatter of the next). At a limit, above all of these: compound 2.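

Among the compounds shown here, at this position on the shared core, the earlier compounds stayed weak in this assay, but furan-3-yl shows that the group here can change the number greatly: a 170-fold lower number from compound 1 to compound 4 (2.22 log units; beyond the scatter) and a 130-fold lower number from compound 3 to compound 4 (2.13 log units; beyond the scatter) are both large. A ring bonded directly to this carbon is not enough on its own, as compound 2 and compound 3 also carry one, 4-fluorophenyl and 4-chlorophenyl, without any comparable gain. Compound 2 stands at a limit of the assay, not at a number, so an at least 330-fold lower number from compound 2 to compound 4 (2.52 log units; beyond the scatter) gives only a floor for this step: the limit of > 100000 nM in this assay, at which 1 of the 4 values shown sits.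

Whether the gain belongs to furan-3-yl in particular stays open, as the compounds shown do not include a close relative at this position, such as furan-2-yl, thiophen-3-yl or a ring carrying an amine. Nothing given here bears on why this single change has so large an effect.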